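This account rests on a few compounds, and the source may have more. Where it says the series, first, only, none or still open, it means among the compounds named here.

Of the compounds shown here, two have so far been tested for how strongly they damage mouse fibroblast cells, in an ADME assay on NIH3T3 cells (Mus musculus) for cytotoxicity, read by CCK-8 assay, with a stated time of 24 h; a higher number here means a weaker inhibitor, a lower number a stronger inhibitor. Compound 1, `C/C(=C\c1cc(C2=CCCCC2)co1)C(N)=O`, gives > 50000 nM, which is a limit of the assay rather than a number. Compound 2, `C/C(=C\c1cccc(-c2ccccc2)c1)C(N)=O`, gives > 50000 nM, again a limit of the assay rather than a number. Compound 2 therefore stands exactly where the whole set stands so far, namely at the limit of > 50000 nM in this assay, at which 2 of the 2 values shown sit, and no ordering of the two compounds can be read from this. Compound 3, `C/C(=C\c1cccc(-c2ccc(C)cc2)c1)C(N)=O`, has not been measured. It differs from compound 2 in one place: methyl in place of hydrogen on an aromatic carbon. For the measured compounds named here, no measured step of this kind exists, so the step expected in this assay is a step that the limit leaves unreadable from compound 2 to compound 3, no change beyond the scatter. Compound 3 is thus expected to give 70000 nM in this assay, within 20000 nM to 250000 nM, and most probably only a limit would be reported again.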

Compound 3, half-maximal inhibitory concentration: > 50000 nM
Compound 3: only a limit was reported; the forecaster's own chance of this, stated with the estimate: 80%; the middle value lies beyond the limit too.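

No size can be read for the step from compound 2 to compound 3, since both results are limits and not numbers: the limit of > 50000 nM in this assay, at which 3 of the 3 values shown sit.

The compounds shown leave open how the three compare beyond that limit, and whether any change to the shared core would give a measurable value in this assay.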